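Protein disulfide-isomerase inhibitors: chloro replaces methyl

This account rests on a few compounds, and the source may have more. Where it says the series, first, only, none or still open, it means among the compounds named here.

Measured compounds:
compound 1 `Oc1c(C(c2ccc(F)cc2)N2CCCCC2)ccc2nccnc12` — 660 nM
compound 2 `Oc1ccc2[nH]ncc2c1C(c1ccc(-n2cccc2)cc1)N1CCCCC1` — 290 nM
compound 3 `Cc1ccc(C(Nc2ccccn2)c2ccc3cccnc3c2O)cc1` — 460 nM

In an assay for inhibition of protein disulfide-isomerase (Homo sapiens), with a stated time of 1 h (on this read-out lower numbers stand for stronger inhibition and higher numbers for weaker inhibition), compound 1 gives 660 nM, compound 2 gives 290 nM and compound 3 gives 460 nM. Compound 3 stands as the second highest of the three numbers, but its gaps to compound 1 and to compound 2 both lie within the usual scatter, so the three cannot be placed in order on these values.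

Compound 4 `Oc1c(C(Nc2ccccn2)c2ccc(Cl)cc2)ccc2cccnc12` is the next candidate and differs from compound 3 in one place: chloro in place of methyl on an aromatic carbon. Among the measured compounds shown here, no step between measured compounds of this kind is available, so only the single value of compound 3 anchors the expectation. The step from compound 3 to compound 4 is expected to be small in this assay, without clear direction and within the scatter, namely a 1.1-fold lower number from compound 3 to compound 4 (0.04 log units; within the scatter). Compound 4 is therefore estimated at 420 nM, with a likely range from 150 nM to 1200 nM.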

Compound 4, half-maximal inhibitory concentration: 170 nM
For compound 4 the middle estimate is 2.5-fold (0.39 log units) above the measured one; the range from low to high includes it.
By their numbers in this assay, from the lowest: compounds 4, 2, 3 and 1 (each within the scatter of the next, the first and the last beyond it).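

In this assay, among the compounds shown here, the position para to a large group, on the six-membered aromatic ring of carbon only, is sensitive to a single-atom exchange: chloro in place of methyl gives a 2.7-fold lower number from compound 3 to compound 4 (0.43 log units; beyond the scatter) and is the first readable step. Compounds 1, 2 and 3 differ in more than one place, so they could not show this. Nothing measured here bears on the reason for this step.

Going by these compounds, whether bromo, methoxy or trifluoromethyl at this position would match chloro remains open. So does whether the same exchange would carry over to other cores.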